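One Chlorine, Two Places: From Compound 3 to Compound 4

The source may hold more compounds than are shown below. What is called first, only, known or untested is meant among the compounds shown, and "the series" means these compounds.

Three compounds share one core and differ only in the ring joined to it through a double bond. In a functional assay on the whole organism (plasma) with Mus musculus as the target, with a stated time of 15 days, at a dose of 10 mg/kg by the oral route (on this read-out lower numbers stand for a weaker effect and higher numbers for a stronger effect at the one dose given), compound 1 `COc1ccc(/C=C2\SC(=O)N(Cc3ccc(C)cc3)C2=O)c(OC)c1` gives 21.8%. In this assay compound 2 `Cc1ccc(CN2C(=O)S/C(=C\c3ccc(N(C)C)cc3)C2=O)cc1` gives 14.9%. Compound 3 `Cc1ccc(CN2C(=O)S/C(=C\c3ccccc3Cl)C2=O)cc1` carries a 2-chlorophenyl on that position, and in this assay compound 3 gives 19.2%. Its number sits between the other two, yet the gap to compound 1 and the gap to compound 2 both lie within the usual scatter of this kind of measurement, so the three compounds cannot be told apart on these data.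

Compound 4 `Cc1ccc(CN2C(=O)S/C(=C\c3ccc(Cl)cc3)C2=O)cc1` is not yet measured. It differs from compound 3 in one place: 4-chlorophenyl in place of 2-chlorophenyl on a double-bonded chain carbon bound to a double-bonded ring carbon. For the measured compounds named here, no measured pair here shows what such a change does, and the three measured compounds, with three rather different rings, all land close together. The step from compound 3 to compound 4 in this assay is therefore expected to be small, with no direction beyond the scatter, a number 0.2 percentage points lower from compound 3 to compound 4 (within the scatter). For compound 4 the expected value in this assay is 19%, between 8% and 32%.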

Compound 4, a percentage reported as activity, at one dose (the size of the read-out at that dose, not a potency): 18.7%
For compound 4 the middle estimate is 0.3 percentage points above the measured one; the measured number falls inside the stated range.
By their numbers in this assay, from the lowest: compounds 2, 4, 3 and 1 (each within the scatter of the next).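

In this assay, for the compounds shown here, moving the chlorine, with 4-chlorophenyl in place of 2-chlorophenyl, gives a number 0.5 percentage points lower from compound 3 to compound 4 (within the scatter) and so offers the first direct look at a single change on this ring: on these data, the two placements of the chlorine cannot be told apart. Chloro in place of dimethylamino on an aromatic carbon gives a number 3.8 percentage points higher from compound 2 to compound 4 (within the scatter) and so likewise leaves the two compounds indistinguishable, which means neither single change stands out from the noise of the measurement. Nothing at hand speaks to what lies behind these results. 

On these data alone, whether a carboxylic acid or a longer chain on this ring would give a number clearly apart from these remains open. As far as these compounds go, what a change on the other side of the shared core would do also stays open, as all four compounds carry the same group there.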